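The source may report more compounds than this note shows. Statements on the series, on what has been measured and on what is new or still open speak of the compounds shown alone.

Three compounds share one core. In a functional assay on the whole organism for inhibition, with Mus musculus as the target, at a dose of 32 mg/kg by the oral route (on this read-out lower numbers stand for less inhibition and higher numbers for more inhibition at the one dose given (going by the name of the read-out)), compound 1 `CSc1ccc2c(c1)c(O)c(C(=O)N(C)c1ccccc1)c(=O)n2C` gives 100%, and compound 2 `CCSc1ccc2c(c1)c(O)c(C(=O)N(C)c1ccccc1)c(=O)n2C` gives 100%. Compound 3 `CCn1c(=O)c(C(=O)N(C)c2ccccc2)c(O)c2cc(SC)ccc21` gives 83%, the lowest of the three numbers. The step of a number 17 percentage points lower from compound 1 to compound 3 (beyond the scatter) shows this, whereas the step of no change at the digits printed from compound 1 to compound 2 (within the scatter) shows no effect at the sulfur-bound carbon.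

Compound 4 `COCn1c(=O)c(C(=O)N(C)c2ccccc2)c(O)c2cc(SC)ccc21` differs from compound 3 by methoxy in place of methyl on a saturated chain carbon bound to an aromatic nitrogen. Within the data shown here, no measured step swaps methyl for methoxy at this carbon; the only step at this carbon was a modest loss, and the other measured step was flat. With so little to go on, a step of a number 3 percentage points lower from compound 3 to compound 4 (within the scatter) within the scatter is expected. Compound 4 is therefore estimated at 80%, with a range from 55% to 100%.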

Compound 4, a percentage reported as inhibition, in the whole organism at one dose (the size of the read-out at that dose, not a potency): 78%
Compound 4: middle estimate off by 2 percentage points, on the high side; the range from low to high includes it.
By their numbers in this assay, from the lowest: compounds 4 and 3 (each within the scatter of the next); then compounds 1 and 2 (each within the scatter of the next).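

At the carbon bound to the aromatic nitrogen, methoxy in place of methyl gives a number 5 percentage points lower from compound 3 to compound 4 (within the scatter) in this assay, so adding the oxygen shows no readable effect here. Methoxy in place of hydrogen gives a number 22 percentage points lower from compound 1 to compound 4 (beyond the scatter), so a second group at this carbon, besides the methyl of compound 3, also sits beyond the scatter from compound 1. Nothing available explains this drop. The compounds shown leave open whether a longer chain or an amine on this carbon would hold the number or lower it further.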